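The source may report more compounds than this note shows. Statements on the series, on what has been measured and on what is new or still open speak of the compounds shown alone.

The series rests on the core shared by compound 1 `CCN1CCN(CCCSc2nnc(-c3ccc(C)cc3)[nH]2)CC1`, compound 2 `Cc1cccc(-c2nnc(SCCCN3CCN(c4ccccc4)CC3)[nH]2)c1` and compound 3 `Cc1cccc(-c2nnc(SCCCN3CCN(c4ccccn4)CC3)[nH]2)c1`, and is judged in a functional assay on COLO 205 cells (Homo sapiens) for cytotoxicity, read by MTT assay, with a stated time of 24 h; on this read-out higher numbers stand for weaker inhibition and lower numbers for stronger inhibition. In this assay compound 1 gives only a limit, > 300000 nM, and no number. In this assay compound 2 likewise gives only a limit, > 300000 nM. In this assay compound 3 also gives only a limit, > 300000 nM. Among the compounds with values here, the one step between measured compounds that differ in a single place, a step that the two limits leave unreadable from compound 2 to compound 3, therefore cannot be read, since both ends are limits. Compound 3 thus stands where every measured compound stands: at the limit of > 300000 nM in this assay, at which 3 of the 3 values shown sit.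

Compound 4 `c1ccc(Cc2nnc(SCCCN3CCN(c4ccccn4)CC3)[nH]2)cc1` is the next compound, and it differs from compound 3 by benzyl in place of 3-methylphenyl on an aromatic carbon. No measured step bears on this change, and the single measured step in this assay is itself unreadable, so nothing in the numbers shown points either up or down. Given that compound 3 gives only a limit in this assay, compound 4 is expected to sit at the same limit, with a step that the limit leaves unreadable from compound 3 to compound 4 expected to be no readable step. For compound 4 the estimate in this assay is 500000 nM, in a range from 200000 nM to 2000000 nM, most probably reported again only as a limit.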

Compound 4, half-maximal inhibitory concentration: > 300000 nM
Compound 4: no number, only a limit (the forecaster's own chance of this, stated with the estimate: 85%); the middle value is on the limit's open side.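

Compound 4, like compound 3, gives only a limit and no number in this assay, so the step between compound 3 and compound 4 cannot be read: the limit of > 300000 nM in this assay, at which 4 of the 4 values shown sit.

The compounds shown leave open whether any change on the shared core can bring a readable value in this assay, and which groups would matter for it.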